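The source may report more compounds than this note shows. Statements on the series, on what has been measured and on what is new or still open speak of the compounds shown alone.

Measured in a functional assay on the whole organism for inhibition, with Scenedesmus acutus as the target; a lower number here means a stronger inhibitor, a higher number a weaker inhibitor
compound 1 `O=C1C2=C(CCCC2)C(=O)N1c1ccc(Cl)cc1F` gives 37.2 nM
compound 2 `CCCOC(=O)c1cc(N2C(=O)C3=C(CCCC3)C2=O)c(F)cc1Cl` gives 33.1 nM
compound 3 `CCCOC(=O)c1cc(N2C(=O)C3=C(CCCC3)C2=O)ccc1Cl` gives 1120 nM

Compound 3, at 1120 nM, has the highest number of the three, and both other compounds lie beyond the scatter from it. Compound 4 `CCCCCCCCOC(=O)c1cc(N2C(=O)C3=C(CCCC3)C2=O)ccc1Cl` differs from compound 3 only in the ester chain, which goes from propyl to octyl (pentyl in place of hydrogen on a saturated chain carbon, three bonds along the chain from an oxygen next to a carbonyl group) .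

Two measured steps are available. The step of a 1.1-fold lower number from compound 1 to compound 2 (0.05 log units; within the scatter) lies within the scatter and brings in propoxycarbonyl in place of hydrogen on an aromatic carbon. The step of a 34-fold higher number from compound 2 to compound 3 (1.53 log units; beyond the scatter) is large and puts hydrogen in place of fluoro on an aromatic carbon. Neither step alters the chain length, so the data hold no direct measure of this change. Compound 4 has no fluoro, as in compound 3, so compound 3 is the proper starting point, and the large step is not expected to recur.

In this assay the central expectation is therefore no step beyond the scatter, with wide uncertainty in both directions. The estimate corresponds to an expected 1.3-fold higher number from compound 3 to compound 4 (0.13 log units; within the scatter). For compound 4 the estimated value is 1500 nM, with an expected range of 300 nM to 8000 nM.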

Compound 4, half-maximal inhibitory concentration: > 100000 nM
Compound 4: only a limit was reported (the forecaster's own chance of this, stated with the estimate: 10%); middle value at least 66-fold (1.82 log units) away from the limit.
By their numbers in this assay, from the lowest: compounds 2 and 1 (each within the scatter of the next); then compound 3. At a limit, above all of these: compound 4.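

Until now the ester chain stood at propyl in every ester shown, so the series said nothing about how the chain itself bears on the read-out. In this assay, lengthening propyl to octyl, the pentyl in place of hydrogen on a saturated chain carbon, gives an at least 89-fold higher number from compound 3 to compound 4 (1.95 log units; beyond the scatter), so this position of the ester chain does not accept the extension in a compound without fluoro, and the step stands as a second large one in the series alongside a 34-fold higher number from compound 2 to compound 3 (1.53 log units; beyond the scatter). Compound 4 carries a limit of the assay and not a number, so the true size of the step stays unknown on its upper side: the limit of > 100000 nM in this assay, at which 1 of the 4 values shown sits.

As far as these compounds go, whether the octyl ester gives the same large step with the fluoro retained, as in compound 2, remains open, as only a compound without fluoro carries the octyl chain here. Also open, from the compounds shown here alone, is how the read-out moves with intermediate chains such as butyl or hexyl, where along the chain the loss sets in, and how a free carboxylic acid in place of the ester would read.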